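The source may report more compounds than this note shows. Statements on the series, on what has been measured and on what is new or still open speak of the compounds shown alone.

Compound 1 `N#Cc1ccc(S(=O)(=O)Nc2cccc3cc[nH]c23)cc1` gives 4.2 ug/mL
Compound 2 `COc1ccc(S(=O)(=O)Nc2cccc3c(C#N)c[nH]c23)cc1` gives 0.17 ug/mL

Both numbers come from a functional assay on P388 cells (Mus musculus) for antiproliferative activity (on this read-out higher numbers stand for weaker inhibition and lower numbers for stronger inhibition), and they are the only two so far. Compound 2 holds the lower number of the pair, which makes it the stronger inhibitor, and its gap to compound 1 lies beyond the scatter. Next comes compound 3 `N#Cc1ccc(S(=O)(=O)Nc2cccc3c(C#N)c[nH]c23)cc1` which keeps all of compound 2 except one group: cyano in place of methoxy on an aromatic carbon, para to a large group (cyano in place of methoxy on an aromatic carbon).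

Within the data shown here, no measured pair shows this exchange on its own. Compound 1 carries cyano at that place, but it also lacks a nitrile found on the core of compound 2. The higher number of compound 1 (4.2 ug/mL) therefore cannot be credited to either difference alone. It still hints at direction, so a modest move toward a higher number, meaning weaker inhibition, is expected, though it may stay within the scatter. The expected size is a 2.4-fold higher number from compound 2 to compound 3 (0.37 log units; beyond the scatter) as an estimate. For compound 3 the estimated value is 0.4 ug/mL with an expected range from 0.1 ug/mL to 1.5 ug/mL as the likely span.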

Compound 3, half-maximal inhibitory concentration: 0.53 ug/mL
Compound 3: middle estimate off by 1.3-fold (0.12 log units), on the low side; measured number inside the range.
By their numbers in this assay, from the lowest: compound 2; then compound 3; then compound 1.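

Compound 3 separates the two differences that were tangled together in compound 1, and each can now be read alone. With the nitrile on the core held constant, cyano in place of methoxy on the six-membered ring, para to a large group, gives a 3.1-fold higher number from compound 2 to compound 3 (0.49 log units; beyond the scatter), so methoxy at this place goes with stronger inhibition in this assay, while adding the nitrile to the core, with cyano held constant on that ring, gives a 7.9-fold lower number from compound 1 to compound 3 (0.90 log units; beyond the scatter), and both steps lie beyond the scatter. The weaker inhibition of compound 1 therefore matches both of its differences pointing the same way, but nothing available here explains why either change moves the number as it does.

Methoxy and cyano are only two possible groups at this place on the ring, so it remains open whether an amine, a chlorine atom or a longer chain such as ethoxy would match methoxy or surpass it. Going by these compounds, the gain from the core nitrile has also been read only with cyano on the ring, so it is unknown whether it would hold with methoxy there, or whether a carboxylic acid on the core could replace that nitrile.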